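Carboxy in Place of Hydrogen on a Piperidinone Chain

A few compounds are considered here, and "the series" means these few. Any claim that something is new, unique, unknown or untested is made for them only; others in the source may bear on it.

Among the measured compounds shown here, compound 1 `CCC(=O)N1C/C(=C\c2cc(OC)c(OC)c(OC)c2)C(=O)/C(=C/c2cc(OC)c(OC)c(OC)c2)C1` is one of two compounds measured in a functional assay on NCI-H460 cells (Homo sapiens) for cytotoxicity, read by MTT assay, with a stated time of 72 h (a lower number here means a stronger inhibitor, a higher number a weaker inhibitor), and in this assay compound 1 gives 2700 nM. That is the lowest of the two numbers. Its nearest neighbour, compound 2 `COc1ccc(/C=C2\CNC/C(=C\c3ccc(OC)c(OC)c3)C2=O)cc1OC`, gives 6400 nM in this assay, a gap that lies beyond the usual scatter; compound 2 differs from compound 1 in more than one place, so nothing is drawn from that pair about any single change.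

Compound 3 `COc1cc(/C=C2\CN(C(=O)CCC(=O)O)C/C(=C\c3cc(OC)c(OC)c(OC)c3)C2=O)cc(OC)c1OC` has not been measured. It differs from compound 1 in one place: carboxy in place of hydrogen on a saturated chain carbon, two bonds along the chain from a carbonyl carbon. For the measured compounds named here, no pair of measured compounds shows this kind of change, so there is no direct guide to its effect. Reasoning from the two numbers at hand, a small weakening is expected, a 1.7-fold higher number from compound 1 to compound 3 (0.22 log units; within the scatter), with an outcome close to compound 1 still possible. Compound 3 is estimated at 4500 nM, within a range of 1500 nM to 14000 nM.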

Compound 3, half-maximal inhibitory concentration: > 60000 nM
Compound 3: no number, only a limit; the forecaster's own chance of this, stated with the estimate: 5%; middle value at least 13-fold (1.12 log units) from the limit.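

In this assay, this position does not accept every change: carboxy in place of hydrogen on a saturated chain carbon, two bonds along the chain from a carbonyl carbon, brings an at least 22-fold higher number from compound 1 to compound 3 (1.34 log units; beyond the scatter). The propanoyl chain of compound 1 is therefore not a place where changes pass unnoticed, something the earlier pair, differing in more than one place, could not show. The result for compound 3 is a limit of the assay, not a number: the limit of > 60000 nM in this assay, at which 1 of the 3 values shown sits.

As far as these compounds go, with a single step on this chain, it remains open whether the loss belongs to the carboxy group itself or would come with other groups on the same carbon. A methyl ester, an amine or a hydroxy group in that place would help to separate these two readings.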